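Swapping a Phenol Hydroxy for a Dimethylamino Side Chain

The source may hold more compounds than are shown below. What is called first, only, known or untested is meant among the compounds shown, and "the series" means these compounds.

Compound 1, `CCOC(=O)c1cccc(-c2ccc(O)cc2)c1`, carries a hydroxy on an aromatic carbon of a six-membered aromatic ring of carbon only. Among the measured compounds shown here, in an assay on COS-7 cells for inhibition of patatin-like phospholipase domain-containing protein 2 (Mus musculus), tested at 200 uM (on this read-out higher numbers stand for more inhibition at the one concentration tested (going by the name of the read-out) and lower numbers for less inhibition), compound 1 gives 77%, the higher of the two numbers measured so far. For the measured compounds named here, its only measured companion is compound 2, `CCOC(=O)c1cccc(-c2ccc(CN3CCN(S(C)(=O)=O)CC3)o2)c1`, which in this assay gives 66%, a value that sits lower than that of compound 1 by a gap beyond the usual scatter. Compound 2 differs from compound 1 in several places at once, so no single structural step can be read from these two values.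

The unmeasured compound 3, `CCOC(=O)c1cccc(-c2ccc(C(C)N(C)C)cc2)c1`, differs from compound 1 in one place only: 1-(dimethylamino)ethyl in place of hydroxy on an aromatic carbon. Going by the values given here, no measured pair shows what this swap does, so the expectation rests on compound 1 alone and is uncertain. A modest downward step is expected, though a step within the scatter cannot be excluded. The change from compound 1 to compound 3 is estimated at a number 15 percentage points lower from compound 1 to compound 3 (beyond the scatter). Compound 3 is therefore expected to give about 62%, most likely between 38% and 84%.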

Compound 3, a percentage reported as inhibition, at one concentration (the size of the read-out at that concentration, not a potency): 50%
Estimate against measurement, compound 3: 12 percentage points above, within the range that was stated.
By their numbers in this assay, from the lowest: compound 3; then compound 2; then compound 1.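

Among the compounds shown here, this is the first change in one place only that can be read in this assay: with 1-(dimethylamino)ethyl in place of hydroxy on an aromatic carbon, para to a large group, the read-out moves to a number 27 percentage points lower from compound 1 to compound 3 (beyond the scatter). The position is therefore not indifferent to what it carries, although compound 3 still gives 50% at the one concentration tested, so inhibition does not vanish with the hydroxy gone. The swap removes the hydrogen-bond donor and brings in a group with more heavy atoms in a single move, and nothing at hand explains the drop or separates these two changes.

From the compounds shown here alone, what stays open is whether the lower number follows from losing the hydroxy or from the particular group that entered. A methoxy or a plain amine at this place would speak to the first question, and a dimethylaminomethyl, which lacks the branching methyl of 1-(dimethylamino)ethyl, or a longer chain ending in the same amine, would speak to the second.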